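Chalcone dithiocarbamates: halogen swap on the styryl ring

A few compounds are considered here, and "the series" means these few. Any claim that something is new, unique, unknown or untested is made for them only; others in the source may bear on it.

Two measured compounds share a core built from a chalcone linked through a three-carbon chain to a dithiocarbamate. Compound 1 `CN1CCN(C(=S)SCCCOc2ccc(C(=O)/C=C/c3ccc(Cl)cc3)cc2)CC1` carries a 4-chlorophenyl group and gives 34200 nM in a functional assay on ECa-109 cells for inhibition, with ECa-109 cell line (Homo sapiens) as the target, read by MTT assay, with a stated time of 72 h; a lower number here means a stronger inhibitor, a higher number a weaker inhibitor. Compound 2 `COc1cc(/C=C/C(=O)c2ccc(OCCCSC(=S)N3CCCC3)cc2)cc(OC)c1OC` carries a trimethoxyphenyl group and a pyrrolidine dithiocarbamate, and in this assay compound 2 gives 11100 nM. Compound 1 stands as the higher of the two numbers, the weaker inhibitor, by a gap beyond the scatter. For the measured compounds named here, no pair differing in one place has been measured, so no step size is known.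

Compound 3 `CN1CCN(C(=S)SCCCOc2ccc(C(=O)/C=C/c3cc(F)cc(F)c3)cc2)CC1` differs from compound 1 only on the styryl ring: 3,5-difluorophenyl in place of 4-chlorophenyl on a double-bonded chain carbon bound to a double-bonded chain carbon. Going by the values given here, with no measured step to lean on, the expected step from compound 1 to compound 3 is a 1.1-fold lower number from compound 1 to compound 3 (0.06 log units; within the scatter), small and within the scatter. Compound 3 is therefore estimated at 30000 nM, with a range from 10000 nM to 90000 nM.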

Compound 3, half-maximal inhibitory concentration: 14500 nM
Beside the measured number, compound 3's estimate is 2.1-fold (0.32 log units) above it; the range from low to high includes it.
By their numbers in this assay, from the lowest: compounds 2 and 3 (each within the scatter of the next); then compound 1.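

In this assay, for the compounds shown here, the step of a 2.4-fold lower number from compound 1 to compound 3 (0.37 log units; beyond the scatter) is modest but beyond the scatter, and it is the first measured size for any change on a double-bonded chain carbon bound to a double-bonded chain carbon. With the rest of the core of compound 1 unchanged, the swap to 3,5-difluorophenyl shows that the number responds to the substituents on this aryl group alone. The swap changes both the halogen and its placement on the ring, so a single step cannot assign the gain to either, and nothing available explains the change.

Open, going by these compounds, is whether a 3,5-dichlorophenyl or a 4-fluorophenyl group would separate halogen identity from placement, and how an unsubstituted phenyl would compare. Also open, on these data alone, is whether the same swap carries over to the pyrrolidine dithiocarbamate of compound 2.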